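Ring Contraction of the Basic Amine in Compound 2

A few compounds are considered here, and "the series" means these few. Any claim that something is new, unique, unknown or untested is made for them only; others in the source may bear on it.

Compound 2 `COc1ccc(-c2ccnc(C(=O)Nc3ccc(Oc4ccnc5cc(OCCCN6CCCCC6)c(OC)cc45)c(F)c3)c2)cc1` gives 570 nM in a functional assay on MKN-45 cells (Homo sapiens) for cytotoxicity, read by MTT assay, with a stated time of 72 h (a lower number here means a stronger inhibitor, a higher number a weaker inhibitor), the highest of the three numbers recorded. Compound 1 `COc1cc2c(Oc3ccc(NC(=O)c4cc(-c5ccccc5F)ccn4)cc3F)ccnc2cc1OCCCN1CCCCC1` gives 180 nM, and compound 3 `COc1cc2c(Oc3ccc(NC(=O)c4cc(-c5ccccc5F)ccn4)cc3F)ccnc2cc1OCCCN1CCN(C)CC1` gives 150 nM. The step of a 3.2-fold higher number from compound 1 to compound 2 (0.50 log units; beyond the scatter) concerns the aryl substituent, whereas a 1.2-fold lower number from compound 1 to compound 3 (0.08 log units; within the scatter) concerns the amine at the end of the chain. Compound 4 `COc1ccc(-c2ccnc(C(=O)Nc3ccc(Oc4ccnc5cc(OCCCN6CCCC6)c(OC)cc45)c(F)c3)c2)cc1` differs from compound 2 by pyrrolidin-1-yl in place of piperidin-1-yl on a saturated chain carbon, three bonds along the chain from an oxygen on an aromatic ring. Going by the values given here, only the step from compound 1 to compound 3 touches this amine, and it stayed within the scatter, so no step beyond the scatter is expected in this assay for compound 4. Compound 4 is therefore estimated at 500 nM, with a range from 200 nM to 1300 nM. This estimate is expected to mean a 1.1-fold lower number from compound 2 to compound 4 (0.06 log units; within the scatter).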

Compound 4, half-maximal inhibitory concentration: 150 nM
Estimate against measurement, compound 4: 3.3-fold (0.52 log units) above, outside the stated range (below it).
By their numbers in this assay, from the lowest: compounds 3, 4 and 1 (each within the scatter of the next); then compound 2.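

In this assay the change to pyrrolidin-1-yl on the saturated chain carbon gives a 3.8-fold lower number from compound 2 to compound 4 (0.58 log units; beyond the scatter) and so shows that this position can move the number beyond the scatter, which a 1.2-fold lower number from compound 1 to compound 3 (0.08 log units; within the scatter) did not show. That earlier step involves a different amine on compounds carrying 2-fluorophenyl rather than 4-methoxyphenyl, so the two steps do not show whether the ring change would act alike on both. Still open, from the compounds shown here alone, is what pyrrolidin-1-yl does with 2-fluorophenyl, and what a dimethylamino group or morpholine does on this chain. No evidence here explains the step.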